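The source may hold more compounds than are shown below. What is called first, only, known or untested is meant among the compounds shown, and "the series" means these compounds.

In an assay on CHO cells for displacement of a labelled ligand from metabotropic glutamate receptor 2 (Homo sapiens), read by scintillation counting, with a stated time of 60 min (a higher number here means a weaker inhibitor, a lower number a stronger inhibitor), compound 1 `COc1ccc(F)cc1C1CCN(c2ccn3c(CC4CC4)nnc3c2Cl)CC1` gives 11.2 nM, compound 2 `COc1c(F)ccc(F)c1C1CCN(c2ccn3c(CC4CC4)nnc3c2Cl)CC1` gives 9.23 nM, and compound 3 `COc1ccc(F)c(F)c1C1CCN(c2ccn3c(CC4CC4)nnc3c2Cl)CC1` gives 7.3 nM. Compound 3 carries the lowest of the three numbers, but its separations from the others, a 1.5-fold lower number from compound 1 to compound 3 (0.19 log units; within the scatter) and a 1.3-fold lower number from compound 2 to compound 3 (0.10 log units; within the scatter), are within the scatter, so no order among the three can be claimed. Compound 4 `COc1cc(F)cc(F)c1C1CCN(c2ccn3c(CC4CC4)nnc3c2Cl)CC1` differs from compound 3 by 2,4-difluoro-6-methoxyphenyl in place of 2,3-difluoro-6-methoxyphenyl on a saturated ring carbon. For the measured compounds named here, the steps that bear on this change are the ones that likewise exchange one substituted phenyl group for another on the same saturated ring carbon: a 1.2-fold lower number from compound 1 to compound 2 (0.08 log units; within the scatter) and a 1.3-fold lower number from compound 2 to compound 3 (0.10 log units; within the scatter), both within the scatter, together with a 1.5-fold lower number from compound 1 to compound 3 (0.19 log units; within the scatter), also within the scatter. Every shift of fluorine on this phenyl group seen so far has left this assay essentially unchanged, so compound 4 is expected to show no step beyond the scatter, the estimated step being a 1.2-fold higher number from compound 3 to compound 4 (0.07 log units; within the scatter). Compound 4 is therefore estimated at 8.5 nM, with a range from 3.5 nM to 22 nM.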

Compound 4, half-maximal inhibitory concentration: 5.6 nM
Compound 4: the middle estimate sits 1.5-fold (0.18 log units) above what was measured; the measured number falls inside the stated range.
By their numbers in this assay, from the lowest: compounds 4, 3, 2 and 1 (each within the scatter of the next).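

A third fluorine arrangement on the phenyl group, the 2,4-difluoro-6-methoxyphenyl group on this saturated ring carbon, still gives no step beyond the scatter in this assay (a 1.3-fold lower number from compound 3 to compound 4 (0.12 log units; within the scatter); a 1.6-fold lower number from compound 2 to compound 4 (0.22 log units; within the scatter)). The widest step among the four compounds also stays within the scatter (a 2.0-fold lower number from compound 1 to compound 4 (0.30 log units; within the scatter)), so across this set neither the placement of the fluorines nor the presence of a second one separates the compounds, and none goes against this. Nothing available bears on why this position is so flat.

The compounds shown all keep the methoxy group and fluorine, so it remains open whether an ethoxy or hydroxyl group, or a chlorine or nitrile, on this phenyl group would give a step beyond the scatter. From the compounds shown here alone, whether a phenyl group with no fluorine, or a pyridine ring in its place, would do so is equally open.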